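Replacing chloromethyl with 4,4-difluorocyclohexyl in compound 3

This account rests on a few compounds, and the source may have more. Where it says the series, first, only, none or still open, it means among the compounds named here.

In a functional assay on A549 cells (Homo sapiens) for cytotoxicity, read by MTT assay, with a stated time of 48 h (on this read-out higher numbers stand for weaker inhibition and lower numbers for stronger inhibition), compound 3 (`C=C1C(=O)O[C@H]2CC3=C[C@H](C/C(C)=C/[C@@H](OC(=O)CCl)[C@H]12)OC3=O`) gives > 10000 nM and this is a limit, not a number. Compound 1 (`C=C1C(=O)O[C@H]2CC3=C[C@H](C/C(C)=C/[C@@H](OC(=O)c4ccc([N+](=O)[O-])cc4)[C@H]12)OC3=O`) also gives only a limit (> 10000 nM). Compound 2 (`C=C1C(=O)O[C@H]2CC3=C[C@H](C/C(C)=C/[C@@H](OC(=O)c4ccc(C(C)=O)cc4)[C@H]12)OC3=O`) gives a true number (2300 nM). Compound 4 (`C=C1C(=O)O[C@H]2CC3=C[C@H](C/C(C)=C/[C@@H](OC(=O)C4CCC(F)(F)CC4)[C@H]12)OC3=O`) carries 4,4-difluorocyclohexyl in place of chloromethyl on a carbonyl carbon. The closest guide is an at least 4.3-fold higher number from compound 2 to compound 3 (0.63 log units; beyond the scatter) for chloromethyl in place of 4-acetylphenyl. Yet an at least 4.3-fold lower number from compound 1 to compound 2 (0.63 log units; beyond the scatter) shows that a larger group alone does not guarantee a number, since 4-nitrophenyl stays at the limit. The expected change is therefore small and toward stronger inhibition, estimated as an at least 1.6-fold lower number from compound 3 to compound 4 (0.22 log units; that floor lies within the scatter) in this assay overall. Compound 4 is estimated at 6000 nM with an expected range from 1800 nM to 20000 nM and a limit reading remains possible.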

Compound 4, half-maximal inhibitory concentration: 6400 nM
Estimate against measurement, compound 4: 1.1-fold (0.03 log units) below, and the stated range covers the measured number.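

In this assay, within the data shown here, compound 4 gives a true number rather than a limit, so a non-aromatic ring on this carbonyl carbon can give a readable value, which among the earlier compounds only the 4-acetylphenyl of compound 2 did. Against that aromatic group the ring still falls short, with a 2.8-fold higher number from compound 2 to compound 4 (0.44 log units; beyond the scatter). The other two comparisons, an at least 1.5-fold lower number from compound 3 to compound 4 (0.19 log units; that floor lies within the scatter) and an at least 1.5-fold lower number from compound 1 to compound 4 (0.19 log units; that floor lies within the scatter), give only floors that rest on a limit: the limit of > 10000 nM in this assay, at which 2 of the 4 values shown sit.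

The compounds shown leave open what the two fluorines add compared with plain cyclohexyl. They also leave open whether a ring carrying an amine or a carboxylic acid would give a lower number here.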